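The source may report more compounds than this note shows. Statements on the series, on what has been measured and on what is new or still open speak of the compounds shown alone.

Measured so far:
- compound 1, `CNCc1cc(-c2cccnc2F)n(S(=O)(=O)c2cccc(F)c2)c1`: in a functional assay on the whole organism (strain Jcl:SD) for inhibition, with Rattus norvegicus as the target, with stated times of 3 min and 3 h, at a dose of 1 mg/kg by the intravenous route (on this read-out higher numbers stand for more inhibition at the one dose given (going by the name of the read-out) and lower numbers for less inhibition), compound 1 gives 99%
- compound 2, `CNCc1cc(-c2cccnc2F)n(S(=O)(=O)c2ccco2)c1`: in this assay compound 2 gives 74%

Compound 2 stands lowest of the two numbers; its nearest neighbour is compound 1, and the step of a number 25 percentage points lower from compound 1 to compound 2 (beyond the scatter) is beyond the scatter, though modest. Compound 3, `CNCc1cc(-c2cccnc2F)n(S(=O)(=O)c2ccc(OC)nc2)c1`, is not yet measured. It differs from compound 2 at the sulfonyl sulfur: 6-methoxypyridin-3-yl in place of furan-2-yl on a sulfonyl sulfur. Among the measured compounds shown here, the only measured step bearing on this position is a number 25 percentage points lower from compound 1 to compound 2 (beyond the scatter), in which a six-membered aromatic ring on the sulfonyl sulfur gave way to furan-2-yl. For the measured compounds named here, compound 3 returns a six-membered aromatic ring to that place, so a step back upward, of about the same size as that one, is expected in this assay, though with only one step to go on the size is uncertain. Compound 3 is therefore estimated at 90%, with a range from 72% to 99%, an expected step of a number 16 percentage points higher from compound 2 to compound 3 (beyond the scatter).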

Compound 3, a percentage reported as inhibition, in the whole organism at one dose (the size of the read-out at that dose, not a potency): 97%
Compound 3: middle estimate off by 7 percentage points, on the low side; low and high end bracket the measured number.
By their numbers in this assay, from the lowest: compound 2; then compounds 3 and 1 (each within the scatter of the next).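

In this assay, the step back from the furan-2-yl, a number 23 percentage points higher from compound 2 to compound 3 (beyond the scatter), shows that the lower number of compound 2 is not fixed by the rest of the molecule and that the sulfonyl sulfur substituent alone can account for a difference of this size. The exchange of one six-membered aromatic ring for another, a number 2 percentage points lower from compound 1 to compound 3 (within the scatter), leaves compound 1 and compound 3 indistinguishable, so this position accepts both 3-fluorophenyl and 6-methoxypyridin-3-yl, and among the three compounds only the furan-2-yl compound stands apart. Nothing at hand gives a reason for this separation.

Among the compounds shown here, whether the separation follows ring size or is particular to furan-2-yl remains open, since only one five-membered ring appears here. Also open, as far as these compounds go, is how a saturated group such as cyclohexyl, a longer alkyl chain, or a phenyl ring bearing a carboxylic acid would read on the sulfonyl sulfur.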